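A few compounds are considered here, and "the series" means these few. Any claim that something is new, unique, unknown or untested is made for them only; others in the source may bear on it.

Measured set, inhibition in a functional assay on Huh-7 cells (Homo sapiens) for inhibition, read by sulforhodamine B assay, with a stated time of 72 h; a higher number here means a weaker inhibitor, a lower number a stronger inhibitor:
- compound 1 `COc1ccc(C2=Nn3c(nnc3C(C)c3ccc4cc(OC)ccc4c3)SC2)cc1`, which gives 8500 nM
- compound 2 `CC(C)Cc1ccc(C(C)c2nnc3n2N=C(c2ccc(Br)cc2)CS3)cc1`, which gives 4900 nM
- compound 3 `COc1ccc2cc(C(C)c3nnc4n3N=C(c3ccc(Br)cc3)CS4)ccc2c1`, which gives 9300 nM

Compound 2 carries the lowest of the three numbers in this assay, yet its gaps to compound 1 and to compound 3 both lie within the scatter, so no ordering among the three can be claimed. Among the measured compounds shown here, the one single-point step in the set, a 1.1-fold higher number from compound 1 to compound 3 (0.04 log units; within the scatter), also stays within the scatter.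

Compound 4 `CC(C)Cc1ccc(C(C)c2nnc3n2N=C(c2ccccc2)CS3)cc1` differs from compound 2 in one place: hydrogen in place of bromo on an aromatic carbon. For the measured compounds named here, no measured pair reports hydrogen in place of bromo on an aromatic carbon, so no step bears directly on this change. The step from compound 1 to compound 3 exchanges one group for another on an aromatic carbon and was flat; it offers no more than a weak hint that the group on that aromatic carbon is not decisive in this assay. With the bromo removed, a step of no more than scatter size is expected for compound 4, the direction undetermined, with a slight lean toward a higher number.

Compound 4 is expected to give 6500 nM in this assay, with a range from 3000 nM to 14000 nM. The expected step of a 1.3-fold higher number from compound 2 to compound 4 (0.12 log units; within the scatter) stays within the scatter.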

Compound 4, half-maximal inhibitory concentration: 6100 nM
Compound 4: the middle estimate sits 1.1-fold (0.03 log units) above what was measured; the range from low to high includes it.
By their numbers in this assay, from the lowest: compounds 2, 4, 1 and 3 (each within the scatter of the next).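

In this assay the change from 4-bromophenyl to phenyl gives a 1.2-fold higher number from compound 2 to compound 4 (0.10 log units; within the scatter) and so cannot be told apart from no change, which shows that the bromo can be removed outright from this aromatic carbon without a step beyond the scatter. The earlier step, a 1.1-fold higher number from compound 1 to compound 3 (0.04 log units; within the scatter), was only an exchange of one group for another at this place, on a different remainder of the molecule; the unsubstituted phenyl now adds hydrogen to methoxy and bromo as a third case, and the flat result holds with a second remainder, though each comparison rests on a single pair. No measurement in hand offers a reason for this flat result.

From the compounds shown here alone, whether an amine or a carboxylic acid on this aromatic carbon, in place of the bromo, would give a step beyond the scatter remains open, since the three groups seen so far cover only a narrow choice. Going by these compounds, with compounds 2, 4, 1 and 3 each within the scatter of the next in this assay, it also remains open which part of the molecule, if any, governs the number.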